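The source may report more compounds than this note shows. Statements on the series, on what has been measured and on what is new or still open speak of the compounds shown alone.

Working notes on a series of three compounds compared in a functional assay on BC1 cells (Homo sapiens) for cytotoxicity; on this read-out higher numbers stand for an effect only at larger amounts of compound and lower numbers for an effect already at smaller amounts. The measured set comprises compound 1 `CCCCCCCCO[C@@H]1O[C@@H](C)[C@H](OC(=O)CCCCC)[C@@H](O[C@@H]2O[C@@H](C)[C@H](OC(C)=O)[C@@H](O[C@@H]3O[C@@H](C)[C@H](O)[C@@H](O)[C@H]3OC(C)=O)[C@H]2OC(C)=O)[C@H]1O`, compound 2 `CCCCCCCCO[C@@H]1O[C@@H](C)[C@H](OC(=O)CCCCC)[C@@H](O[C@@H]2O[C@@H](C)[C@H](OC(C)=O)[C@@H](O[C@@H]3O[C@@H](C)[C@H](OC(C)=O)[C@@H](OC(C)=O)[C@H]3O)[C@H]2OC(C)=O)[C@H]1O` and compound 3 `CCCCCCCCO[C@@H]1O[C@@H](C)[C@H](OC(=O)CCCCC)[C@@H](O[C@@H]2O[C@@H](C)[C@H](OC(C)=O)[C@@H](OC(C)=O)[C@H]2OC(C)=O)[C@H]1O`. In this assay compound 1 gives > 20 ug/mL, which is a limit of the assay and not a number. In this assay compound 2 gives > 20 ug/mL, again a limit. In this assay compound 3 gives > 20 ug/mL, also a limit. For the measured compounds named here, compound 2 thus stands exactly where the whole set stands, at the limit of > 20 ug/mL in this assay, at which 3 of the 3 values shown sit, so no ordering among the three compounds can be drawn and no step between any two of them can be sized.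

The unmeasured compound 4 `CCCCCCCCO[C@@H]1O[C@@H](C)[C@H](OC(=O)CCCCC)[C@@H](O[C@@H]2O[C@@H](C)[C@H](OC(C)=O)[C@@H](O[C@@H]3O[C@@H](C)[C@H](OC(C)=O)[C@@H](O)[C@H]3O)[C@H]2OC(C)=O)[C@H]1O` differs from compound 2 in one place: hydrogen in place of acetyl on an oxygen on a saturated carbon. All other parts of the shared core of compound 2 are kept. Going by the values given here, with no measured step anywhere in the set, there is nothing to suggest that removing one acetyl would move the read-out, and the expectation is that the step that the limit leaves unreadable from compound 2 to compound 4 stays within the usual scatter, in no particular direction. Compound 4 is accordingly expected to give 30 ug/mL in this assay, within a range from 15 ug/mL to 100 ug/mL, and most probably to be reported only as a limit once more.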

Compound 4, concentration for half-maximal effect: > 20 ug/mL
Compound 4 was reported as a limit (the forecaster's own chance of this, stated with the estimate: 85%); the middle value does not contradict the limit.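

In this assay compound 2 and compound 4 both stand at a limit of the assay and not at a number, so no new step can be read between them: the limit of > 20 ug/mL in this assay, at which 4 of the 4 values shown sit. The compounds shown leave open whether any member of the series gives a measurable effect on this read-out, and so whether the change from acetoxy to hydroxy moves it at all.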